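Removing the fluoro from the benzamide of compound 2

The source may hold more compounds than are shown below. What is called first, only, known or untested is meant among the compounds shown, and "the series" means these compounds.

Measured compounds:
compound 1, `COc1ccc(S(=O)(=O)N2CCc3cccc(NCc4ccccc4)c32)cc1`, > 10000 nM
compound 2, `COc1ccc(S(=O)(=O)N2CCc3cccc(NC(=O)c4ccc(F)cc4)c32)cc1`, 100 nM

In a functional assay on TSGH 9201 cells (Homo sapiens) for cytotoxicity (on this read-out lower numbers stand for stronger inhibition and higher numbers for weaker inhibition), compound 1 gives only a limit, > 10000 nM; this is the limit of > 10000 nM in this assay, at which 1 of the 2 values shown sits. In this assay, among the measured compounds shown here, compound 2 gives 100 nM, the only number. The step of an at least 100-fold lower number from compound 1 to compound 2 (2.00 log units; beyond the scatter) replaces one group with another on the nitrogen on the aromatic ring. Compound 3, `COc1ccc(S(=O)(=O)N2CCc3cccc(NC(=O)c4ccccc4)c32)cc1`, differs from compound 2 by hydrogen in place of fluoro on an aromatic carbon. For the measured compounds named here, no measured step alters the carbonyl-bearing ring itself, so the one measured step bears only loosely on this change; the fluoro on compound 2 is a small part of the group that entered in the step from compound 1. No step beyond the scatter is expected in this assay for this change. Compound 3 is estimated at 150 nM, between 50 nM and 450 nM, an expected step of a 1.5-fold higher number from compound 2 to compound 3 (0.18 log units; within the scatter).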

Compound 3, half-maximal inhibitory concentration: 201 nM
Compound 3: the middle estimate sits 1.3-fold (0.13 log units) below what was measured; low and high end bracket the measured number.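

In this assay, removing the fluoro gives a 2.0-fold higher number from compound 2 to compound 3 (0.30 log units; within the scatter), so the two compounds cannot be told apart on this read-out and the fluoro is not required for activity at this level. Without the fluoro, benzoyl in place of benzyl on the nitrogen still gives an at least 49-fold lower number from compound 1 to compound 3 (1.69 log units; beyond the scatter), which ties the large gain to the carbonyl rather than to the fluoro. Compound 1 gives only a limit, so the size of this step is a bound and not a measured difference: the limit of > 10000 nM in this assay, at which 1 of the 3 values shown sits.

On these data alone, only fluoro and hydrogen are compared at this place, para to a large group, so it remains open whether a larger group such as methoxy or dimethylamino would be tolerated there. As far as these compounds go, whether the amide hydrogen matters also remains open, as would be tested by a methyl on the amide nitrogen.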